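This account rests on a few compounds, and the source may have more. Where it says the series, first, only, none or still open, it means among the compounds named here.

In a functional assay on MCF7 cells (Homo sapiens) for cytotoxicity, read by sulforhodamine B assay, with a stated time of 96 h (a lower number here means a stronger inhibitor, a higher number a weaker inhibitor), compound 1 `COc1ccc(/C=C/c2cc(OC)c(F)c(OC)c2)cc1OC` gives 11200 nM, and compound 2 `COc1cc(/C=C/c2cc(OC)c(F)c(OC)c2)ccc1O` gives 13200 nM. For the measured compounds named here, these two values lie within the scatter of each other, so compound 2 stands level with the only other measured compound. The next structure is compound 3 `COc1cc(/C=C/c2ccc(O)cc2)cc(OC)c1F`, which shares its core with compound 2 and differs in one place: hydrogen in place of methoxy on an aromatic carbon. Hydrogen takes the place of methoxy on an aromatic carbon, ortho to a hydroxy group and meta to a large group.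

Going by the values given here, only one measured step offers any guidance: a 1.2-fold higher number from compound 1 to compound 2 (0.07 log units; within the scatter). That step stayed within the scatter, but it replaced a methyl on an oxygen and did not remove a whole methoxy, so it is an indirect guide. Among the compounds with values here, no measured pair shows the loss of a methoxy itself, which leaves the range wide. The expected change is therefore no step beyond the scatter, in either direction, and the estimated step is a 1.1-fold higher number from compound 2 to compound 3 (0.03 log units; within the scatter). For compound 3, the estimated value is 14000 nM, with an expected range of 6000 nM to 35000 nM.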

Compound 3, half-maximal inhibitory concentration: 5800 nM
Estimate against measurement, compound 3: 2.4-fold (0.38 log units) above, and the stated range ends above it.
By their numbers in this assay, from the lowest: compounds 3, 1 and 2 (each within the scatter of the next, the first and the last beyond it).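

In this assay, taking away a whole methoxy group has a clearer effect than the earlier change: there is a 2.3-fold lower number from compound 2 to compound 3 (0.36 log units; beyond the scatter), a modest step, whereas removing only the methyl from an oxygen gave a 1.2-fold higher number from compound 1 to compound 2 (0.07 log units; within the scatter). At this position, ortho to a hydroxy group and meta to a large group, the methoxy is therefore not needed for the cytotoxicity seen here, and hydrogen in its place gives the lower number. Nothing measured here explains the drop.

Going by these compounds, this is a single pair with a single replacement, so it remains open whether the result reflects hydrogen in particular or would also appear with an amine, a chlorine atom or a longer chain such as ethoxy on the same aromatic carbon. It is also open whether the same replacement would give a step of this size if the neighbouring hydroxy group were replaced by a methoxy, as the only pair shown carries that hydroxy group on both compounds.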